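Fluorophenyl Replaces Naphthyl on a Fused Bicyclic Core

The source may hold more compounds than are shown below. What is called first, only, known or untested is meant among the compounds shown, and "the series" means these compounds.

Measured compounds:
Compound 1, `c1ccc(-c2cn3ccnc3c(-c3ccc4ncn(C5CCCCC5)c4c3)n2)cc1`: 49%
Compound 2, `O=Cc1ccc(-c2cn3ccnc3c(-c3ccc4ncn(C5CCCCC5)c4c3)n2)cc1`: 3.69%
Compound 3, `c1ccc2c(-c3cn4ccnc4c(-c4ccc5ncn(C6CCCCC6)c5c4)n3)cccc2c1`: 11.1%

In a functional assay on KM12 cells (Homo sapiens) for inhibition, read by sulforhodamine B assay, with a stated time of 48 h, tested at 10 uM (on this read-out higher numbers stand for more inhibition at the one concentration tested (going by the name of the read-out) and lower numbers for less inhibition), compound 1 gives 49%. Compound 2 gives 3.69%, and compound 3 gives 11.1%. Compound 3 therefore sits far beneath compound 1, the step of a number 37.9 percentage points lower from compound 1 to compound 3 (beyond the scatter) being large, while its gap to compound 2 is small: a number 7.4 percentage points higher from compound 2 to compound 3 (within the scatter).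

Compound 4, `Fc1ccc(-c2cn3ccnc3c(-c3ccc4ncn(C5CCCCC5)c4c3)n2)cc1`, has not been measured. Relative to compound 3 the change is 4-fluorophenyl in place of naphthalen-1-yl on an aromatic carbon.

Among the compounds with values here, two measured steps bear on this. The step of a number 37.9 percentage points lower from compound 1 to compound 3 (beyond the scatter) shows that replacing a single ring by the two-ring group costs much inhibition; compound 4 returns to a single six-membered aromatic ring of carbon only, so the reverse movement is expected. The step of a number 45.3 percentage points lower from compound 1 to compound 2 (beyond the scatter), however, shows that a group placed on that single ring can remove almost all inhibition. Fluorine is a different substituent from the one in compound 2, and the data offer no direct measurement of its effect.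

Compound 4 is therefore expected to rise toward compound 1, with the step estimated as a number 23.9 percentage points higher from compound 3 to compound 4 (beyond the scatter), though with wide uncertainty. The estimate for compound 4 is 35%, within a range of 10% to 58%.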

Compound 4, a percentage reported as inhibition, at one concentration (the size of the read-out at that concentration, not a potency): 3.49%
The estimate for compound 4 lay 31.5 percentage points above the measured number; the measured number lies below the stated range.
By their numbers in this assay, from the lowest: compounds 4, 2 and 3 (each within the scatter of the next); then compound 1.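

In this assay, the step of a number 45.5 percentage points lower from compound 1 to compound 4 (beyond the scatter) shows that a single fluoro on the phenyl ring at this position is enough to lose most of the inhibition, so the loss seen with the formyl group is not confined to that group. Fluoro and formyl cannot be told apart here, with the step of a number 0.2 percentage points lower from compound 2 to compound 4 (within the scatter) leaving them level, and going from the two-ring naphthalen-1-yl to the one-ring 4-fluorophenyl restores nothing, with the step of a number 7.6 percentage points lower from compound 3 to compound 4 (within the scatter) also lying inside the usual spread, so a single carbon ring alone does not bring inhibition back and, among these four compounds, only the unsubstituted phenyl of compound 1 stands apart. Nothing given here accounts for why this one added atom has so large an effect.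

As far as these compounds go, it remains open whether every group on this ring gives the same loss, or whether a methyl, a hydroxyl or an amine in the same place would keep some inhibition. From the compounds shown here alone, it is equally open whether fluoro on a different carbon of the phenyl ring would behave like the 4-fluorophenyl group.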